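Cyclobutyl amide in place of an oxanylethyl chain

The compounds below may be only part of what the source reports. "The series", "measured", "known", "first", "only" and "open" are said of these compounds alone.

Three compounds of this series have been examined in a physicochemical assay for solubility (a lower number here means a less soluble compound, a higher number a more soluble compound), and in each case only a limit was reported. Compound 1 `CNC(=O)c1cc(C(=O)NC2CCC2)cn(Cc2ccncc2)c1=O` gives >= 118 ug/mL in this assay, which is a limit rather than a measured number. Compound 3 `CNC(=O)c1cc(C(=O)NC2CC2)cn(CC2CCCOC2)c1=O` likewise gives >= 131 ug/mL, again a limit. Compound 2 `CNC(=O)c1cc(C(=O)NCCC2CCOCC2)cn(Cc2ccccc2)c1=O` stands at >= 127 ug/mL in this assay, also a limit. Within the data shown here, because all three values rest at limits, no step between measured compounds can be sized and no ordering among them can be drawn.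

Compound 4 `CNC(=O)c1cc(C(=O)NC2CCC2)cn(Cc2ccccc2)c1=O` differs from compound 2 in one place: cyclobutyl in place of 2-(oxan-4-yl)ethyl on an amide-type nitrogen. Nothing measured here shows how such a change moves solubility, so the expected step of an at least 1.0-fold lower number from compound 2 to compound 4 (0.02 log units; that floor lies within the scatter) is taken as none beyond the scatter. Compound 1, which also carries cyclobutylamino, gives >= 118 ug/mL, a limit. On that basis compound 4 is expected to remain well soluble, and it is estimated at 120 ug/mL in this assay. The range for compound 4 is expected to run from 45 ug/mL to 200 ug/mL, with a fair chance that this assay again reports only a limit.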

Compound 4, solubility: 28 ug/mL
Compound 4: middle estimate off by 4.3-fold (0.63 log units), on the high side, outside the stated range (below it).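

Among these compounds, compound 4 gives the first number that is not a limit in this assay, and it shows that neither of its two places is indifferent: cyclobutyl in place of 2-(oxan-4-yl)ethyl on an amide-type nitrogen gives an at least 4.5-fold lower number from compound 2 to compound 4 (0.65 log units; beyond the scatter), and phenyl in place of pyridin-4-yl on a saturated chain carbon bound to an aromatic nitrogen gives an at least 4.2-fold lower number from compound 1 to compound 4 (0.62 log units; beyond the scatter). Cyclobutylamino with pyridin-4-yl in compound 1 and phenyl with (2-(oxan-4-yl)ethyl)amino in compound 2 both stay at limits, and of these three only compound 4 carries cyclobutylamino together with phenyl. Compound 2 stands only at a limit, so the step from it is a floor and not a size: the limit of >= 127 ug/mL in this assay, at which 1 of the 4 values shown sits.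

Going by these compounds, how far compound 1 lies past its limit stays open, which leaves the step from it a floor as well: the limit of >= 118 ug/mL in this assay, at which 1 of the 4 values shown sits. It also remains open whether an amine or a carboxylic acid on the amide-type nitrogen, with phenyl kept, would stay near the number of compound 4 or return to a limit.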